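The compounds below may be only part of what the source reports. "The series", "measured", "known", "first", "only" and "open" are said of these compounds alone.

Measured compounds:
- compound 1 `COc1ccc(-c2cc(/C=C/C(=O)c3ccc(N)cc3)[nH]n2)cc1`: 64300 nM
- compound 2 `COc1cc(-c2cc(/C=C/C(=O)c3ccc(Cl)c(Cl)c3)[nH]n2)cc(OC)c1OC`: > 100000 nM

In a functional assay on CAKI-1 cells (Homo sapiens) for inhibition, read by sulforhodamine B assay, with a stated time of 48 h (on this read-out higher numbers stand for lower toxicity in this test and lower numbers for higher toxicity in this test), compound 1 gives 64300 nM. For compound 2 the result in this assay is a limit of the test and not a number, > 100000 nM. For the measured compounds named here, of the two values recorded, compound 2 is the one that sits at the limit of > 100000 nM in this assay, at which 1 of the 2 values shown sits, so it stands at the edge of what this test resolves, and compound 1 holds the only measured number.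

Compound 3 `COc1ccc(C(=O)/C=C/c2cc(-c3cc(OC)c(OC)c(OC)c3)n[nH]2)cc1OC` is not yet measured. It differs from compound 2 by 3,4-dimethoxyphenyl in place of 3,4-dichlorophenyl on a carbonyl carbon. Going by the values given here, no step between two measured compounds covers this exchange, and compound 1 carries a different group on the carbonyl carbon as well as on the shared core, so its value gives no direct reading of the change. The expected step of an at least 1.1-fold lower number from compound 2 to compound 3 (0.04 log units; that floor lies within the scatter) is none beyond the scatter, and a limit again seems likely. Compound 3 is expected to give 90000 nM in this assay, within 30000 nM to 300000 nM.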

Compound 3, concentration lethal to 50% of the cells: 19400 nM
For compound 3 the middle estimate is 4.6-fold (0.67 log units) above the measured one, outside the stated range (below it).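

In this assay, 3,4-dimethoxyphenyl in place of 3,4-dichlorophenyl on a carbonyl carbon gives an at least 5.1-fold lower number from compound 2 to compound 3 (0.71 log units; beyond the scatter), so the group at this position can move the read-out beyond the scatter on an otherwise unchanged compound. For compound 2 the result is a limit of the test, > 100000 nM. The full size of the step stays open because one end of it is that limit: the limit of > 100000 nM in this assay, at which 1 of the 3 values shown sits.

Whether the change follows from gaining the methoxy groups or from losing the chlorines is not settled by this single pair, and an unsubstituted phenyl or a 3,4-difluorophenyl group on the same carbonyl carbon would separate the two. Compound 1 differs from both other compounds in more than one place, so its value does not bear on this exchange.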